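The source may report more compounds than this note shows. Statements on the series, on what has been measured and on what is new or still open speak of the compounds shown alone.

Measured compounds in a functional assay on A549 cells (Homo sapiens) for antiproliferative activity, read by MTT assay, with a stated time of 72 h; a higher number here means a weaker inhibitor, a lower number a stronger inhibitor:
compound 1 `C#Cc1cccc(Nc2ncnc3cc(OC)c(OCCCCC(=O)Nc4ccc(S(N)(=O)=O)cc4)cc23)c1` gives 7720 nM
compound 2 `COc1cc2ncnc(Nc3ccc(Cl)cc3)c2cc1OCCCCC(=O)Nc1ccc(S(N)(=O)=O)cc1` gives > 40000 nM
compound 3 `COc1cc2ncnc(Nc3cccc(Cl)c3F)c2cc1OCCCCC(=O)Nc1ccc(S(N)(=O)=O)cc1` gives 10500 nM

The value of compound 2 is a limit of this assay, not a number. Compound 3 and compound 1 sit together: the step of a 1.4-fold higher number from compound 1 to compound 3 (0.13 log units; within the scatter) is within the scatter. Compound 2 stands apart from both, as an at least 5.1-fold higher number from compound 1 to compound 2 (0.71 log units; beyond the scatter) and an at least 3.8-fold lower number from compound 2 to compound 3 (0.58 log units; beyond the scatter) show.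

Compound 4 `COc1cc2ncnc(Nc3cccc(C)c3)c2cc1OCCCCC(=O)Nc1ccc(S(N)(=O)=O)cc1` is not yet measured. It differs from compound 3 by 3-methylphenyl in place of 3-chloro-2-fluorophenyl on a nitrogen on an aromatic ring. Within the data shown here, the steps that bear on this change are those among the three anilines: two 3-substituted phenyls gave numbers within the scatter of each other, while the 4-chlorophenyl in compound 2 reached only the limit (the limit of > 40000 nM in this assay, at which 1 of the 3 values shown sits). Compound 4 keeps a 3-substituted phenyl, so a weaker but still measurable number is expected; the estimated step of a 1.4-fold higher number from compound 3 to compound 4 (0.15 log units; within the scatter) is modest, and compound 4 is expected at about 15000 nM, between 6000 nM and 40000 nM.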

Compound 4, half-maximal inhibitory concentration: 16000 nM
Beside the measured number, compound 4's estimate is 1.1-fold (0.03 log units) below it, and the stated range covers the measured number.
By their numbers in this assay, from the lowest: compounds 1, 3 and 4 (each within the scatter of the next, the first and the last beyond it). At a limit, above all of these: compound 2.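

In this assay, 3-methylphenyl in place of 3-chloro-2-fluorophenyl gives a 1.5-fold higher number from compound 3 to compound 4 (0.18 log units; within the scatter), so neither chlorine nor fluorine is needed for a measurable number at this nitrogen. Yet methyl in place of ethynyl gives a 2.1-fold higher number from compound 1 to compound 4 (0.32 log units; beyond the scatter), the first step beyond the scatter among these 3-substituted phenyls, while 3-methylphenyl in place of 4-chlorophenyl gives an at least 2.5-fold lower number from compound 2 to compound 4 (0.39 log units; beyond the scatter). The value of compound 2 is a limit, not a number: the limit of > 40000 nM in this assay, at which 1 of the 4 values shown sits.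

The compounds shown do not tell where a 3-methoxyphenyl or a 3-cyanophenyl on this nitrogen would fall. They also leave open whether a shorter or longer chain to the sulfonamide would move these numbers.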